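Fluoro to hydrogen on the aryl ring of compound 3

A few compounds are considered here, and "the series" means these few. Any claim that something is new, unique, unknown or untested is made for them only; others in the source may bear on it.

Three compounds have been measured in an assay on isolated protein for inhibition of tissue alpha-L-fucosidase (Bos taurus), tested at 1000 uM; a lower number here means less inhibition, a higher number more inhibition at the concentration tested (going by the name of the read-out):

compound 1 `COc1ccc([C@]2(CO)NC[C@@H](O)[C@@H]2O)cc1` gives 2.7%
compound 2 `COc1cccc([C@]2(CO)NC[C@@H](O)[C@@H]2O)c1` gives 0%
compound 3 `OC[C@@]1(c2ccc(F)cc2)NC[C@@H](O)[C@@H]1O` gives 0%

Among the compounds with values here, compound 3 stands level with compound 2 at the digits reported, and the two together sit at the bottom of the three numbers; no step between them is computed, their two values simply agree. Compound 1 lies above compound 3 by a number 2.7 percentage points lower from compound 1 to compound 3 (within the scatter), which is within the scatter of this assay, so none of the three compounds can be set apart from the others.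

The next compound, compound 4 `OC[C@@]1(c2ccccc2)NC[C@@H](O)[C@@H]1O`, is reached from compound 3 by a single change: hydrogen in place of fluoro on an aromatic carbon, on an aromatic carbon of a six-membered aromatic ring of carbon only, para to a group of 9 heavy atoms. Within the data shown here, the one measured step that bears on this position, a number 2.7 percentage points lower from compound 1 to compound 3 (within the scatter), exchanged one substituent on that same aromatic carbon for another and moved the read-out by an amount within the scatter. Removing the fluoro altogether is therefore expected to leave the inhibition essentially unchanged, with no step beyond the scatter: the expected step is a number 1.5 percentage points higher from compound 3 to compound 4 (within the scatter). For compound 4 the estimate in this assay is 1.5%, in a range from 0% to 10%.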

Compound 4, a percentage reported as inhibition, at one concentration (the size of the read-out at that concentration, not a potency): 0%
The estimate for compound 4 lay 1.5 percentage points above the measured number; the range from low to high includes it.
By their numbers in this assay, from the lowest: compounds 2, 3, 4 and 1 (each within the scatter of the next).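

Compound 4 carries no substituent on this ring, so the aromatic carbon that holds the fluoro can now be read against plain hydrogen in this assay, and that exchange gives (no change at the digits printed from compound 3 to compound 4 (within the scatter)). Hydrogen in place of methoxy reads the same way for both methoxy compounds, with (no change at the digits printed from compound 2 to compound 4 (within the scatter)) and (a number 2.7 percentage points lower from compound 1 to compound 4 (within the scatter)), so neither fluoro nor methoxy can be told apart from hydrogen on this ring in this read-out. No evidence is at hand that would explain this flat result.

All four numbers lie so close together and so near the bottom of the read-out that the series shows no response to work from, and a group that raised the inhibition would be needed before this position could be judged at all. Going by these compounds, it remains open whether a carboxylic acid, an amine or a longer chain on this aromatic carbon would lift the number, or whether a change elsewhere on the shared core would do so.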